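Furan-3-yl replaces a pyridinylmethyl arm at the limit

This account rests on a few compounds, and the source may have more. Where it says the series, first, only, none or still open, it means among the compounds named here.

In a functional assay on cells (Platelet, Homo sapiens) for inhibition (on this read-out higher numbers stand for weaker inhibition and lower numbers for stronger inhibition), compound 1 `CCOC(=O)c1ccc(-c2nn(Cc3ccc(F)cc3)c3ccccc23)cc1` gives > 10000 nM, which is a limit of the assay and not a number. Compound 2 `CCOC(=O)c1ccc(-c2nn(Cc3ccccn3)c3ccccc23)cc1` gives > 10000 nM, which is likewise a limit. What is known so far therefore comes down to the limit of > 10000 nM in this assay, at which 2 of the 2 values shown sit. For the measured compounds named here, the only measured step is a step that the two limits leave unreadable from compound 1 to compound 2, so it offers no size to carry forward.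

The next structure, compound 3 `CCOC(=O)c1ccc(-c2nn(-c3ccoc3)c3ccccc23)cc1`, carries furan-3-yl in place of (pyridin-2-yl)methyl on an aromatic nitrogen. Going by the values given here, no measured compound yet shows a readable inhibition, so nothing supports a direction for this change. The only anchor is the limit of compound 2, > 10000 nM, so little movement is expected in this assay, and another reading at the limit is the likeliest outcome. The step expected is a number no higher from compound 2 to compound 3 (the limit leaves the size open). For compound 3 the estimated value is 10000 nM, with an expected range from 3000 nM to 30000 nM.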

Compound 3, half-maximal inhibitory concentration: > 10000 nM
Compound 3: no number, only a limit; the forecaster's own chance of this, stated with the estimate: 75%; the middle value sits exactly at the limit.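

In this assay compound 3 gives > 10000 nM as a limit of the assay and not a number. For the compounds shown here, no step from compound 1 or compound 2 to compound 3 can be read, and the compounds stand together at one reading: the limit of > 10000 nM in this assay, at which 3 of the 3 values shown sit. The compounds shown leave open whether any group on the aromatic nitrogen gives a readable inhibition.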